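The source may report more compounds than this note shows. Statements on the series, on what has been measured and on what is new or still open speak of the compounds shown alone.

Measured so far in a physicochemical assay for solubility, using the shake flask method, measured as kinetic solubility, with a stated time of 20 h, at pH 2; on this read-out lower numbers stand for lower solubility and higher numbers for higher solubility:
Compound 1, `FC(F)(F)Oc1ccc(-c2nc3cnc(Nc4ccccn4)cc3[nH]2)cc1`, gives 26000 nM.
Compound 2, `COc1cccc(Nc2cc3[nH]c(-c4cccc(C(F)(F)F)c4)nc3cn2)n1`, gives 85000 nM.
Compound 3, `COc1ccnc(Nc2cc3[nH]c(-c4cccc(C(F)(F)F)c4)nc3cn2)c1`, gives < 5000 nM, a limit of this assay rather than a number.

Compound 3 therefore sits at the lower edge of the set, at the limit of < 5000 nM in this assay, at which 1 of the 3 values shown sits, while compounds 1 and 2 each gave a number. The one step measured among these compounds that changes the group on the same nitrogen is an at least 17-fold lower number from compound 2 to compound 3 (1.23 log units; beyond the scatter), a large fall in this assay on moving between two isomeric methoxypyridinyl groups.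

Compound 4, `FC(F)(F)c1cccc(-c2nc3cnc(Nc4ncccn4)cc3[nH]2)c1`, has not yet been measured. It differs from compound 3 by pyrimidin-2-yl in place of 4-methoxypyridin-2-yl on a nitrogen on an aromatic ring. Within the data shown here, no measured step pairs a pyrimidin-2-yl with a 4-methoxypyridin-2-yl, so the direction rests only on the fact that compound 3 is at a limit and a change here has already moved this assay strongly once. Compound 4 is expected to give about 8000 nM, with a range from 2000 nM to 40000 nM. The step from compound 3 to compound 4 is thus estimated as an at least 1.6-fold higher number from compound 3 to compound 4 (0.20 log units; that floor lies within the scatter), with a real chance that only a limit is again reported.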

Compound 4, solubility: 155000 nM
Compound 4: middle estimate off by 19-fold (1.29 log units), on the low side; measured number above the stated range.
By their numbers in this assay, from the lowest: compound 1; then compounds 2 and 4 (each within the scatter of the next). At a limit, below all of these: compound 3.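

In this assay, the change to pyrimidin-2-yl on this nitrogen gives an at least 31-fold higher number from compound 3 to compound 4 (1.49 log units; beyond the scatter), so this position has now produced a large rise as well as a large fall. The same group set against the other methoxypyridine gives a 1.8-fold higher number from compound 2 to compound 4 (0.26 log units; within the scatter), so pyrimidin-2-yl and 6-methoxypyridin-2-yl cannot be told apart here, and among these three groups only 4-methoxypyridin-2-yl stands apart. Compound 3 remains at a limit of the assay rather than at a number: the limit of < 5000 nM in this assay, at which 1 of the 4 values shown sits.

The compounds shown leave open how the unsubstituted pyridin-2-yl would compare on this same core, as it appears only in compound 1, which also differs elsewhere. They also leave open how a pyridine ring carrying an amine or a carboxylic acid in place of the methoxy group would read in this assay.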